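Pyridin-4-yl to pyridin-3-yl on the shared core

The source may hold more compounds than are shown below. What is called first, only, known or untested is meant among the compounds shown, and "the series" means these compounds.

For the measured compounds named here, in an ADME assay on Vero cells (Chlorocebus sabaeus) for cytotoxicity, read by MTT assay, with a stated time of 72 h (on this read-out higher numbers stand for lower toxicity in this test and lower numbers for higher toxicity in this test), compound 1 (`Cc1nnc(C2(O)CC(C)CC(C)(C)C2)[nH]1`) gives 380 ug/mL and compound 2 (`CC1CC(C)(C)CC(O)(c2nnc(-c3ccncc3)[nH]2)C1`) gives 414 ug/mL as the only numbers so far. Compound 2 therefore sits within the scatter of compound 1, and the two cannot be ordered.

Compound 3 (`CC1CC(C)(C)CC(O)(c2nnc(-c3cccnc3)[nH]2)C1`) is the next point to be read in this assay and has the same atoms as compound 2, joined differently: pyridin-3-yl in place of pyridin-4-yl on an aromatic carbon on the carbon between two ring nitrogen atoms.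

Going by the values given here, the sole measured step bearing on this change is a 1.1-fold higher number from compound 1 to compound 2 (0.04 log units; within the scatter) on exchanging methyl for pyridin-4-yl, and it stayed within the scatter. Among the compounds with values here, that step concerns a different exchange at the same place, and no measured pair yet compares two pyridine attachments, so the guidance is indirect. Even so, a swap of one pyridinyl group for another gives no ground for expecting more than the methyl exchange produced. The expected change is a 1.0-fold lower number from compound 2 to compound 3 (0.01 log units; within the scatter) and no move beyond the scatter is expected in either direction.

Compound 3 is expected at 400 ug/mL (estimated range 230 ug/mL to 650 ug/mL).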

Compound 3, half-maximal cytotoxic concentration: 368 ug/mL
For compound 3 the middle estimate is 1.1-fold (0.04 log units) above the measured one; measured number inside the range.
By their numbers in this assay, from the lowest: compounds 3, 1 and 2 (each within the scatter of the next).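

For the compounds shown here, exchanging pyridin-4-yl for pyridin-3-yl on the carbon between two ring nitrogen atoms gives a 1.1-fold lower number from compound 2 to compound 3 (0.05 log units; within the scatter) in this assay and provides the first direct comparison of two pyridine attachments at this place, which this read-out does not separate. The exchange of methyl for pyridin-3-yl gives a 1.0-fold lower number from compound 1 to compound 3 (0.01 log units; within the scatter) and so joins the earlier methyl to pyridin-4-yl exchange: all three groups shown at this carbon now lie within the scatter of one another, and the position has not yet produced a step beyond it. No supporting measurement is available to explain why these three compounds read alike.

The groups shown at this carbon are limited to methyl and the two pyridinyl groups, so whether an aminomethyl group, a carboxylic acid or a longer alkyl chain would give a step beyond the scatter remains open. The rest of the shared core is constant across compounds 1 to 3, which also leaves open what a methyl ether in place of its hydroxyl would do in this test.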